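Varying the amide substituent on a vitamin D receptor agonist core

A few compounds are considered here, and "the series" means these few. Any claim that something is new, unique, unknown or untested is made for them only; others in the source may bear on it.

Compounds measured so far:
compound 1, `CCN(CC)CCNC(=O)c1ccc(C(CC)(CC)c2ccc(OCC(=O)C(C)(C)C)c(C)c2)n1CC`, 91 nM
compound 2, `CCN(CC)CCCNC(=O)c1ccc(C(CC)(CC)c2ccc(OCC(=O)C(C)(C)C)c(C)c2)n1CC`, 22 nM
compound 3, `CCn1c(C(=O)NCCN)ccc1C(CC)(CC)c1ccc(OCC(=O)C(C)(C)C)c(C)c1`, 120 nM

In an assay on HL-60 cells for agonist activity at vitamin D3 receptor (Homo sapiens), read by microscopy, with a stated time of 96 h (a higher number here means that more compound is needed for the effect, a lower number that less compound is needed), compound 1 stands second highest of the three numbers. Its nearest neighbour is compound 3, where the step is a 1.3-fold higher number from compound 1 to compound 3 (0.12 log units; within the scatter). The step to compound 2 is a 4.1-fold lower number from compound 1 to compound 2 (0.62 log units; beyond the scatter), and the step of a 5.5-fold higher number from compound 2 to compound 3 (0.74 log units; beyond the scatter) completes the set. All three measured compounds keep the same amide nitrogen and differ only in the chain beyond it.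

Compound 4, `C=CCN(C)C(=O)c1ccc(C(CC)(CC)c2ccc(OCC(=O)C(C)(C)C)c(C)c2)n1CC`, has not yet been measured. It differs from compound 1 by allyl(methyl)amino in place of (2-(diethylamino)ethyl)amino on a carbonyl carbon. The amide hydrogen and the whole aminoethyl chain are gone; what enters is a shorter group with no hydrogen-bond donor or acceptor.

The three measured steps bear on this change only loosely, since each of them keeps an amine at the chain end and the amide hydrogen. They show that altering this chain moves the number by a modest amount, in either direction. Removing the chain altogether is a larger change than any of them, so the expected step for compound 4 is a modestly higher number, a 2.4-fold higher number from compound 1 to compound 4 (0.38 log units; beyond the scatter), with wide uncertainty. Compound 4 is therefore expected to give 220 nM in this assay, in the range 60 nM to 800 nM.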

Compound 4, half-maximal effective concentration: 21600 nM
Compound 4: the middle estimate sits 98-fold (1.99 log units) below what was measured; the whole stated range lies below it.
By their numbers in this assay, from the lowest: compound 2; then compounds 1 and 3 (each within the scatter of the next); then compound 4.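

In this assay, varying the chain while keeping a terminal amine and the amide hydrogen had moved the number only modestly, but this carbonyl carbon proves far less tolerant of a change that removes both. Allyl(methyl)amino is a large step away from each amide with an aminoalkyl chain (a 240-fold higher number from compound 1 to compound 4 (2.38 log units; beyond the scatter); a 180-fold higher number from compound 3 to compound 4 (2.26 log units; beyond the scatter); a 980-fold higher number from compound 2 to compound 4 (2.99 log units; beyond the scatter)). Among the compounds shown, then, an amide hydrogen and a chain ending in an amine occur together in every compound with a low number, and compound 4, which has neither, alone has a high one. Nothing available on these compounds accounts for the size of this step.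

From the compounds shown here alone, what remains open is whether the amide hydrogen, the terminal amine or the shorter group matters most, as compound 4 changes all of these at once. An allylamino group on the same carbonyl carbon, or a (2-(diethylamino)ethyl)(methyl)amino group there, would begin to separate these contributions.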